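The compounds below may be only part of what the source reports. "The series", "measured", "known", "first", "only" and "open" are said of these compounds alone.

Measured so far:
Compound 1 `O=c1cc(NC2CCCCC2)cc(/C=C/c2ccccc2)o1` - 1.25 uM
Compound 2 `COc1cccc(Nc2cc(-c3ccccc3)oc(=O)c2)c1` - 0.63 uM
Compound 3 `COc1ccc(Nc2cc(C)oc(=O)c2)cc1` - > 30 uM

All three were tested in a functional assay on A549 cells (Homo sapiens) for cytotoxicity, read by MTT assay, with a stated time of 72 h; on this read-out higher numbers stand for an effect only at larger amounts of compound and lower numbers for an effect already at smaller amounts. For compound 3, the entry > 30 uM is a limit of the assay and not a number. That leaves two true numbers: compound 2 gives 0.63 uM and compound 1 gives 1.25 uM, and these lie within the usual scatter of each other.

Compound 4 `O=c1cc(Nc2ccccc2)cc(-c2ccccc2)o1` has not yet been measured. It differs from compound 2 by a single change (hydrogen in place of methoxy on an aromatic carbon), with hydrogen in place of methoxy on an aromatic carbon. Going by the values given here, no measured pair isolates this change, so any forecast remains uncertain. Compound 1 carries no methoxy and gives 1.25 uM, so a low number in this assay does not depend on that group. No step beyond the scatter is therefore expected, and the estimated step is a 1.6-fold higher number from compound 2 to compound 4 (0.20 log units; within the scatter). For compound 4, the estimated value is 1 uM, with an expected range from 0.3 uM to 4 uM.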

Compound 4, concentration for half-maximal effect: 0.12 uM
The estimate for compound 4 lay 8.3-fold (0.92 log units) above the measured number; the measured number lies below the stated range.
By their numbers in this assay, from the lowest: compound 4; then compounds 2 and 1 (each within the scatter of the next). At a limit, above all of these: compound 3.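

Going by these compounds alone, the exchange of methoxy for hydrogen, on an aromatic carbon meta to a large group, brings a 5.3-fold lower number from compound 2 to compound 4 (0.72 log units; beyond the scatter) in this assay and gives the first direct reading of a single change at this position. It shows that the methoxy is not needed for a low number here, and that removing it at this position changes the number by more than the usual scatter. The compounds shown offer no explanation for this step.

Still open, from the compounds shown here alone, is whether hydrogen itself is favoured at this position or whether other small groups, such as fluorine or an amine, would do as well. Going by these compounds, it is also open whether moving the methoxy to another carbon of that ring would give a similar number.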